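Chain Extension at Two Different Places in One Amide Series

This account rests on a few compounds, and the source may have more. Where it says the series, first, only, none or still open, it means among the compounds named here.

The measured compounds and their values:
Compound 1, `CCCc1ccc(/C=C/C(=O)Nc2ccc3nc(CCC)cc(N)c3c2)cc1`, 4 nM
Compound 2, `CCCCc1ccc(/C=C/C(=O)Nc2ccc3nc(CCC)cc(N)c3c2)cc1`, 45 nM
Compound 3, `Cc1cc(N)c2cc(NC(=O)/C=C/c3ccc(C(F)(F)F)cc3)ccc2n1`, 8 nM

Three compounds were characterised in an assay on isolated protein for displacement of a labelled ligand from melanin-concentrating hormone receptor 1 (Homo sapiens); on this read-out lower numbers stand for stronger inhibition and higher numbers for weaker inhibition. Compound 1 gives 4 nM, and compound 2 gives 45 nM. The two differ by methyl in place of hydrogen on a saturated chain carbon, three bonds along the chain from an aromatic carbon, and this single change produced an 11-fold higher number from compound 1 to compound 2 (1.05 log units; beyond the scatter). Compound 3 gives 8 nM; the difference between its core and the core of compound 1 is not broken down here, so the two values can only be compared, not traced to one change.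

Compound 4, `CCc1cc(N)c2cc(NC(=O)/C=C/c3ccc(C(F)(F)F)cc3)ccc2n1`, has not yet been measured in this assay. It differs from compound 3 by methyl in place of hydrogen on a saturated chain carbon bound to an aromatic carbon. For the measured compounds named here, this is the same kind of change as the one from compound 1 to compound 2, yet the surroundings are not the same: in the earlier pair the methyl entered on a saturated chain carbon three bonds along the chain from an aromatic carbon, whereas here it enters on a saturated chain carbon bound to an aromatic carbon. Compound 3 carries a shorter chain at this place than compound 1, and because compound 1 gives 4 nM, the longer chain on the core is not expected to cost much. The step from compound 3 to compound 4 is therefore expected to be small, no change at the digits printed from compound 3 to compound 4 (within the scatter), rather than resembling the earlier one. Compound 4 is estimated at 8 nM, with a range of 3 nM to 25 nM.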

Compound 4, half-maximal inhibitory concentration: 1.2 nM
Estimate against measurement, compound 4: 6.7-fold (0.82 log units) above; the whole stated range lies above it.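

In this assay, methyl in place of hydrogen on a saturated chain carbon bound to an aromatic carbon gave a 6.7-fold lower number from compound 3 to compound 4 (0.82 log units; beyond the scatter). Set beside the earlier step, this shows that the same formal change does not carry a fixed effect, or even a fixed direction, from one core to another in this series: the same change on two cores in this assay, an 11-fold higher number (1.05 log units; beyond the scatter) from compound 1 to compound 2 and a 6.7-fold lower number (0.82 log units; beyond the scatter) from compound 3 to compound 4, 75-fold (1.88 log units) apart, beyond the scatter of two such steps It does not show what sets the direction, since the two steps differ in the place of the change as well as in the surrounding structure: one lies on a saturated chain carbon three bonds along the chain from an aromatic carbon, the other on a saturated chain carbon bound to an aromatic carbon, and these two pairs cannot separate the influence of place from that of core.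

The compounds shown leave open how a propyl chain or a longer chain in place of the ethyl of compound 4 would read in this assay, and so whether the gain seen with ethyl continues or reverses as that chain grows. They also leave open whether an amine or a hydroxyl group at the end of that chain would be tolerated.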